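From Compound 2 to Compound 3 on a Thiocarbonyl Carbon

The compounds below may be only part of what the source reports. "The series", "measured", "known", "first", "only" and "open" are said of these compounds alone.

Compound 1 `CCN1CCN(C(=S)SCC(=O)N(Cc2ccc(OC)cc2)c2cc(OC)c(OC)c(OC)c2)CC1`: 9890 nM
Compound 2 `COc1ccc(CN(C(=O)CSC(=S)N2CCc3cc(OC)ccc32)c2cc(OC)c(OC)c(OC)c2)cc1`: 11700 nM

Among the measured compounds shown here, in a functional assay on MGC-803 cells (Homo sapiens) for inhibition, read by CCK-8 assay, with a stated time of 48 h (on this read-out lower numbers stand for stronger inhibition and higher numbers for weaker inhibition), compound 2 lies within the scatter of compound 1, the only other compound measured so far. Compound 3 `COc1ccc(CN(C(=O)CSC(=S)N2CCCc3cc(OC)ccc32)c2cc(OC)c(OC)c(OC)c2)cc1` differs from compound 2 in one place: 6-methoxy-1,2,3,4-tetrahydroquinolin-1-yl in place of 5-methoxy-2,3-dihydro-1H-indol-1-yl on a thiocarbonyl carbon. The change puts 6-methoxy-1,2,3,4-tetrahydroquinolin-1-yl in place of 5-methoxy-2,3-dihydro-1H-indol-1-yl on a thiocarbonyl carbon. For the measured compounds named here, the one measured step at this place, a 1.2-fold higher number from compound 1 to compound 2 (0.07 log units; within the scatter), stayed within the scatter, though only a single step bears on it. No change beyond the scatter is therefore expected in this assay. The expected step is a 1.2-fold lower number from compound 2 to compound 3 (0.07 log units; within the scatter). For compound 3 the estimated value is 10000 nM, with an expected range of 3500 nM to 28000 nM.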

Compound 3, half-maximal inhibitory concentration: 8210 nM
For compound 3 the middle estimate is 1.2-fold (0.09 log units) above the measured one, and the stated range covers the measured number.
By their numbers in this assay, from the lowest: compounds 3, 1 and 2 (each within the scatter of the next).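

In this assay, the change of ring size in the group on the thiocarbonyl carbon gives a 1.4-fold lower number from compound 2 to compound 3 (0.15 log units; within the scatter), and the replacement of 4-ethylpiperazin-1-yl by 6-methoxy-1,2,3,4-tetrahydroquinolin-1-yl gives a 1.2-fold lower number from compound 1 to compound 3 (0.08 log units; within the scatter). Both steps lie within the scatter, so all three groups at this place now stand level, including the two fused groups that differ in one ring. No available evidence accounts for this result. On these data alone, whether a small open-chain amine such as dimethylamino, or a group carrying a carboxylic acid, would also stay within the scatter remains open. The same holds for moving the methoxy group on 6-methoxy-1,2,3,4-tetrahydroquinolin-1-yl or removing it.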